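Swapping trifluoromethoxy for 4-fluorophenoxy: what half-life follows?

The source may report more compounds than this note shows. Statements on the series, on what has been measured and on what is new or still open speak of the compounds shown alone.

In an ADME assay on microsomes (Rattus norvegicus) for metabolic stability (a lower number here means that the compound disappears faster, a higher number that the compound lasts longer), compound 1 `O=c1[nH]nc2ccc(-c3ccc(Oc4ccc(F)cc4)cc3)cn12` gives 0.717 h, compound 2 `Cc1noc(Cn2nc3ccc(-c4ccc(Oc5ccc(F)cc5)cc4)cn3c2=O)n1` gives 1.42 h and compound 3 `Cc1nc(Cn2nc3ccc(-c4ccc(OC(F)(F)F)cc4)cn3c2=O)no1` gives 6.05 h. That last number is the highest of the three, and its gaps to both others lie beyond the usual scatter of repeat measurements.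

Compound 4 `Cc1nc(Cn2nc3ccc(-c4ccc(Oc5ccc(F)cc5)cc4)cn3c2=O)no1` departs from compound 3 by 4-fluorophenyl in place of trifluoromethyl on an oxygen on an aromatic ring, so trifluoromethoxy becomes 4-fluorophenoxy. Compound 4 therefore keeps the side chain of compound 3 and takes up the 4-fluorophenoxy group of compounds 1 and 2.

Going by the values given here, no measured step makes this swap directly. Among the compounds with values here, the only measured step, a 2.0-fold higher number from compound 1 to compound 2 (0.30 log units; within the scatter), installs (3-methyl-1,2,4-oxadiazol-5-yl)methyl in place of hydrogen on an aromatic nitrogen and stays within the scatter. The closest guide is compound 2, which carries 4-fluorophenoxy and a related side chain, at 1.42 h. Three compounds cannot establish a rule, but they point to a lower number. A fall beyond the scatter is expected, with an estimated 3.8-fold lower number from compound 3 to compound 4 (0.58 log units; beyond the scatter) in this assay. For compound 4 the estimated half-life is 1.6 h, with an expected range of 0.7 h to 3.5 h.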

Compound 4, half-life: 2.42 h
The estimate for compound 4 lay 1.5-fold (0.18 log units) below the measured number, and the stated range covers the measured number.
By their numbers in this assay, from the lowest: compounds 1, 2 and 4 (each within the scatter of the next, the first and the last beyond it); then compound 3.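

In this assay, the group on the oxygen now has a step of its own: with the side chain held fixed, 4-fluorophenyl in place of trifluoromethyl gives a 2.5-fold lower number from compound 3 to compound 4 (0.40 log units; beyond the scatter) and is a modest change. On the other side of the molecule, 5-methyl-1,2,4-oxadiazol-3-yl in place of 3-methyl-1,2,4-oxadiazol-5-yl gives a 1.7-fold higher number from compound 2 to compound 4 (0.23 log units; within the scatter) and so cannot be told apart from the scatter, while adding the whole (5-methyl-1,2,4-oxadiazol-3-yl)methyl group in place of hydrogen on the aromatic nitrogen gives a 3.4-fold higher number from compound 1 to compound 4 (0.53 log units; beyond the scatter) and is also modest. Nothing measured here offers an explanation for these steps.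

The compounds shown leave open how a small group such as methyl on the same oxygen would compare with trifluoromethyl and 4-fluorophenyl. They also leave open whether an amine or a carboxylic acid in place of the oxadiazole ring on the saturated chain would change the half-life, and whether trifluoromethoxy would keep its standing with hydrogen on the aromatic nitrogen.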